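Replacing Cyclopropyl with Methylsulfonyl at the Core of Compound 1

This account rests on a few compounds, and the source may have more. Where it says the series, first, only, none or still open, it means among the compounds named here.

Compound 1 `c1ccc2oc(-c3cn4nc(C5CC5)sc4n3)cc2c1` is the weakest of the three measured compounds in a functional assay on HEK293 cells for antagonist activity at proteinase-activated receptor 4 (Homo sapiens), read by FLIPR and calcium flux, with a stated time of 30 min (a higher number here means a weaker inhibitor, a lower number a stronger inhibitor), where compound 1 gives 530 nM. Compound 2 `COc1nn2cc(-c3cc4ccccc4o3)nc2s1` gives 4 nM in this assay, and compound 3 `COc1cc(OCc2cccc(CCc3ccccc3)c2)c2cc(-c3cn4nc(OC)sc4n3)oc2c1` gives 2.4 nM. Compound 4 `CS(=O)(=O)c1nn2cc(-c3cc4ccccc4o3)nc2s1` has not yet been measured; it differs from compound 1 as follows: methylsulfonyl in place of cyclopropyl on an aromatic carbon.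

For the measured compounds named here, only one measured step bears on this change, and it touches the same position with a different group: a 130-fold lower number from compound 1 to compound 2 (2.12 log units; beyond the scatter). That step shows the cyclopropyl can be exchanged at this position with a large gain, but methylsulfonyl is not methoxy, and nothing measured tells how far that gain carries over. He therefore expects a step in this assay toward a lower number, smaller than the one seen for methoxy and with wide uncertainty: a 3.5-fold lower number from compound 1 to compound 4 (0.55 log units; beyond the scatter). His estimate for compound 4 in this assay is 150 nM, within the range 20 nM to 1500 nM.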

Compound 4, half-maximal inhibitory concentration: 820 nM
The estimate for compound 4 lay 5.5-fold (0.74 log units) below the measured number; low and high end bracket the measured number.
By their numbers in this assay, from the lowest: compounds 3 and 2 (each within the scatter of the next); then compounds 1 and 4 (each within the scatter of the next).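

In this assay, methylsulfonyl in place of cyclopropyl on this aromatic carbon gives a 1.5-fold higher number from compound 1 to compound 4 (0.19 log units; within the scatter) and so cannot be told apart from cyclopropyl here. Methylsulfonyl in place of methoxy gives a 210-fold higher number from compound 2 to compound 4 (2.31 log units; beyond the scatter) and thus shows that the large gain seen with methoxy does not extend to every replacement for cyclopropyl at this position, where methoxy alone among these three groups gives the low number. Nothing shown explains why these groups differ in this way.

Going by these compounds, whether an amine, an ethoxy group or a methylthio group on this carbon would match methoxy remains open. On these data alone, it is also open whether methylsulfonyl would give the same result on the larger, more substituted frame of compound 3.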